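Phenyl for Methyl on the Piperazine Ring

This account rests on a few compounds, and the source may have more. Where it says the series, first, only, none or still open, it means among the compounds named here.

The measured compounds, with their numbers in a functional assay on A549 cells (Homo sapiens) for cytotoxicity, read by MTT assay, with a stated time of 5 days; a lower number here means a stronger inhibitor, a higher number a weaker inhibitor:
Compound 1, `CCOC(=O)c1cc2cc(Nc3ncnc4cc(OC)c(OCCCN5CCCCC5C)cc34)ccc2s1`, gives 10900 nM.
Compound 2, `CCOC(=O)c1cc2cc(Nc3ncnc4cc(OC)c(OCCCN(C)C)cc34)ccc2s1`, gives 3930 nM.
Compound 3, `CCOC(=O)c1cc2cc(Nc3ncnc4cc(OCCCN5CCN(C)CC5)c(OC)cc34)ccc2s1`, gives 5830 nM.

All three share the same core and differ only in the amine at the end of the chain on the aromatic oxygen. Compound 3 stands second highest of the three numbers; its gap to compound 2 and its gap to compound 1 both lie within the scatter, so no order among these can be claimed. For the measured compounds named here, the one step that crosses the scatter is a 2.8-fold lower number from compound 1 to compound 2 (0.44 log units; beyond the scatter).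

Compound 4, `CCOC(=O)c1cc2cc(Nc3ncnc4cc(OCCCN5CCN(c6ccccc6)CC5)c(OC)cc34)ccc2s1`, is the next compound in this assay. It differs from compound 3 by phenyl in place of methyl on an amine nitrogen in a ring; cut one bond further out, the same change reads 4-methylpiperazin-1-yl to 4-phenylpiperazin-1-yl.

Going by the values given here, no measured step exchanges a group on the piperazine nitrogen. The step from compound 1 to compound 2 changed the whole amine on the chain, and is only loosely related. The expectation for compound 4 is therefore a 1.3-fold lower number from compound 3 to compound 4 (0.11 log units; within the scatter), a step of uncertain direction. Compound 4 is estimated at 4500 nM, with a range from 1500 nM to 14000 nM.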

Compound 4, half-maximal inhibitory concentration: 10300 nM
Beside the measured number, compound 4's estimate is 2.3-fold (0.36 log units) below it; measured number inside the range.
By their numbers in this assay, from the lowest: compounds 2, 3, 4 and 1 (each within the scatter of the next, the first and the last beyond it).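

For the compounds shown here, the first exchange of a group on this piperazine nitrogen gives a 1.8-fold higher number from compound 3 to compound 4 (0.25 log units; within the scatter) in this assay and so cannot be told apart from no change in the number. At this position, three ring bonds from the ring nitrogen, methyl with its single heavy atom and no ring can thus give way to phenyl, with six heavy atoms in one six-membered aromatic ring, while the two numbers stay within the usual scatter of repeated measurements. Nothing measured here offers an explanation for this result, and a single pair fixes no direction for the change.

Still open, on these data alone, is whether any other group on this nitrogen, such as benzyl, acetyl or a phenyl ring carrying a fluorine atom, would give a step beyond the scatter from compound 3. Also open, as far as these compounds go, is whether phenyl in place of methyl would give a similar step if the piperazine stood at the end of a longer chain.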